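The compounds below may be only part of what the source reports. "The series", "measured", "known", "first", "only" and "open" are said of these compounds alone.

The series shares one core and varies only the group on the oxygen on a saturated carbon. Compound 1 `C#CCO[C@@H]1C=CC(=O)[C@@H](CO)O1` carries a propargyl group there, and in a functional assay on MCF7 cells (Homo sapiens) for inhibition, read by MTT assay, with a stated time of 72 h (on this read-out lower numbers stand for stronger inhibition and higher numbers for weaker inhibition), compound 1 gives 10400 nM. Compound 3 `O=C1C=C[C@@H](OC2CCCCC2)O[C@@H]1CO` carries a cyclohexyl group on the same oxygen, and in this assay compound 3 gives 11000 nM. Compound 1 stands at the lower of the two numbers that have been measured, but its gap to compound 3 lies within the usual scatter, so the two cannot be told apart on these data. Compound 2 `C#CCCO[C@@H]1C=CC(=O)[C@@H](CO)O1` carries a butynyl group on that oxygen, and in this assay compound 2 stands at "not determined" (no result reported), so no number is available for it.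

Compound 4 `O=C1C=C[C@@H](OC2CCCC2)O[C@@H]1CO` differs from compound 1 in one place: cyclopentyl in place of propargyl on an oxygen on a saturated carbon. Within the data shown here, no step between two measured compounds matches this change, yet the pair of compound 1 and compound 3 shows that a propargyl and a saturated carbon ring on this oxygen give numbers within the scatter of each other. On that basis the step in this assay from compound 1 to compound 4 is expected to be small, a 1.0-fold higher number from compound 1 to compound 4 (0.00 log units; within the scatter), with no direction beyond the scatter. Compound 4 is therefore estimated at 10500 nM, within a range from 4500 nM to 25000 nM.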

Compound 4, half-maximal inhibitory concentration: 20700 nM
Compound 4: the middle estimate sits 2.0-fold (0.29 log units) below what was measured; the measured number falls inside the stated range.
By their numbers in this assay, from the lowest: compounds 1, 3 and 4 (each within the scatter of the next).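

In this assay the change on the oxygen on a saturated carbon now has a step of its own: a 2.0-fold higher number from compound 1 to compound 4 (0.30 log units; within the scatter), so replacing propargyl, with its triple bond and no ring, by cyclopentyl, with its five-membered non-aromatic ring, does not move the number beyond the scatter. With compound 3 included, the open-chain propargyl group and the two saturated carbon rings give numbers that each lie within the scatter of the next, so these data show no clear preference among the three groups at this position. No measurement at hand speaks to the reason for this result.

From the compounds shown here alone, what an amine, a carboxylic acid or a phenyl ring on this oxygen would give stays open, since the groups with numbers here are all made of carbon and hydrogen only. Also open is whether a change elsewhere on the shared core would shift the number beyond the scatter, since the compounds shown vary only on this oxygen.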